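A few compounds are considered here, and "the series" means these few. Any claim that something is new, unique, unknown or untested is made for them only; others in the source may bear on it.

Of the compounds shown here, two built on a shared core have so far been measured in a functional assay on the whole organism for inhibition, with Nicotiana tabacum as the target; a higher number here means a weaker inhibitor, a lower number a stronger inhibitor. Compound 1 `Cc1nc(Nc2ccc(Cl)cc2)c2cc[nH]c2n1` gives 224000000 nM in this assay. Within the data shown here, compound 2 `Cc1nc(NC2CCC2)c2cc[nH]c2n1` gives 74100000 nM in this assay, the lower of the two numbers; its only neighbour is compound 1, whose number stands higher by a margin beyond the usual scatter of repeated measurements. Compound 3 `Cc1nc(NCC2CC2)c2cc[nH]c2n1` has not yet been measured in this assay. It differs from compound 2 in a single place: cyclopropylmethyl in place of cyclobutyl on a nitrogen on an aromatic ring. Among the measured compounds shown here, no step between measured compounds shows what such a rearrangement does, so any expectation rests on compound 2 alone, whose value in this assay is 74100000 nM. The two groups hold the same atoms, joined differently. The step from compound 2 to compound 3 is expected to be small, no change at the digits printed from compound 2 to compound 3 (within the scatter), with no direction beyond the scatter. Compound 3 is therefore estimated at 74100000 nM in this assay, within a range from 25000000 nM to 220000000 nM.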

Compound 3, half-maximal inhibitory concentration: 77600000 nM
Compound 3: the middle estimate sits 1.0-fold (0.02 log units) below what was measured; the range from low to high includes it.
By their numbers in this assay, from the lowest: compounds 2 and 3 (each within the scatter of the next); then compound 1.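

In this assay, putting cyclopropylmethyl in place of cyclobutyl on a nitrogen on an aromatic ring gives a 1.0-fold higher number from compound 2 to compound 3 (0.02 log units; within the scatter) and leaves the two compounds within the scatter of each other. At this position, the same atoms can therefore be joined in either of these two ways without a difference that this measurement can separate, something that compound 2 alone could not show. Nothing available explains this result.

What the compounds shown leave open is whether an open-chain butyl group or a larger cyclohexyl ring on this nitrogen would also stay within the scatter of compound 2. They also leave open whether adding a hydroxyl group or a carboxylic acid to the cyclobutyl group would shift the number in this assay beyond the scatter.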